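The source may hold more compounds than are shown below. What is called first, only, known or untested is meant among the compounds shown, and "the series" means these compounds.

Measured so far in a functional assay on T47D cells (Homo sapiens) for antiproliferative activity, read by MTT assay, with a stated time of 24 h; a higher number here means a weaker inhibitor, a lower number a stronger inhibitor
- compound 1 `O=S(=O)(Nc1ccc2cc[nH]c2c1)c1ccc(F)cc1` gives 33000 nM
- compound 2 `Cc1ccc(S(=O)(=O)Nc2ccc3cc[nH]c3c2)cc1` gives 57100 nM
- compound 3 `COc1ccc(S(=O)(=O)Nc2ccc3cc[nH]c3c2)cc1` gives 45000 nM

Compound 3 stands within the scatter of both other compounds, so the three numbers do not separate. Compound 4 `O=S(=O)(Nc1ccc2cc[nH]c2c1)c1ccc(Cl)cc1` is next, with chloro in place of methoxy on an aromatic carbon, para to a large group: chloro in place of methoxy on an aromatic carbon. Three measured exchanges on that carbon bear on it: a 1.7-fold higher number from compound 1 to compound 2 (0.24 log units; within the scatter), a 1.4-fold higher number from compound 1 to compound 3 (0.13 log units; within the scatter) and a 1.3-fold lower number from compound 2 to compound 3 (0.10 log units; within the scatter). All are small and within the scatter, so no step beyond the scatter is expected in this assay. The expected step is a 1.1-fold lower number from compound 3 to compound 4 (0.05 log units; within the scatter). For compound 4 the estimated value is 40000 nM, with an expected range from 22000 nM to 75000 nM.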

Compound 4, half-maximal inhibitory concentration: 46200 nM
Estimate against measurement, compound 4: 1.2-fold (0.06 log units) below, and the stated range covers the measured number.
By their numbers in this assay, from the lowest: compounds 1, 3, 4 and 2 (each within the scatter of the next).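

In this assay chloro does not separate from any other group on this aromatic carbon: a 1.0-fold higher number from compound 3 to compound 4 (0.01 log units; within the scatter) and a 1.2-fold lower number from compound 2 to compound 4 (0.09 log units; within the scatter) and a 1.4-fold higher number from compound 1 to compound 4 (0.15 log units; within the scatter) all stay within the scatter. All four groups, including both halogens, now give numbers that do not separate, and exchanging methoxy, with its hydrogen-bond acceptor, for chloro, with none, produces no readable step. Nothing available explains why this position responds so little.

On these data alone, whether an amine, a carboxylic acid or a longer chain on this carbon would give a step beyond the scatter remains open. So does the effect of any change to the shared core.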